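A few compounds are considered here, and "the series" means these few. Any claim that something is new, unique, unknown or untested is made for them only; others in the source may bear on it.

Going by the values given here, in a physicochemical assay for lipophilicity, read by HPLC, measured as chromatographic lipophilicity, at pH 7.4 (on this read-out higher numbers stand for higher lipophilicity and lower numbers for lower lipophilicity), compound 1 `O=C(c1cccnc1)N1CCC(C(=O)N2N=CCC2c2ccccc2)CC1` gives 2.6 and compound 2 `O=C(c1cn[nH]c1)N1CCC(C(=O)N2N=CCC2c2ccccc2)CC1` gives 2.1, the lower of the two numbers so far. Among the compounds with values here, the one measured step is modest but beyond the scatter: a number 0.50 log units lower from compound 1 to compound 2 (beyond the scatter).

Next is compound 3 `O=C(C1CCN(c2ccccc2)CC1)N1N=CCC1c1ccccc1`, not yet measured in this assay. The change is phenyl in place of (1H-pyrazol-4-yl)carbonyl on an amine nitrogen in a ring.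

The measured step bears on this only in part. It exchanges the group on a carbonyl carbon and keeps the carbonyl, whereas here the carbonyl leaves too. Within the data shown here, no measured step covers that loss, so the size of the new step is poorly anchored. Starting from compound 2 at 2.1 and going by the hydrogen-bond counts in the change, a higher number is expected, by clearly more than the size of a number 0.50 log units lower from compound 1 to compound 2 (beyond the scatter). The expected move is a number 1.70 log units higher from compound 2 to compound 3 (beyond the scatter). Compound 3 is estimated at 3.8, with an expected range from 3.2 to 4.4.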

Compound 3, distribution coefficient: 6.3
Beside the measured number, compound 3's estimate is 2.50 log units below it; the measured number lies above the stated range.
By their numbers in this assay, from the lowest: compound 2; then compound 1; then compound 3.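

In this assay the group on the amine nitrogen in a ring moves the number much further when the carbonyl leaves along with the ring it carries: a number 4.20 log units higher from compound 2 to compound 3 (beyond the scatter) and a number 3.70 log units higher from compound 1 to compound 3 (beyond the scatter) are both large, while a number 0.50 log units lower from compound 1 to compound 2 (beyond the scatter) is modest and comes from exchanging only the group on the carbonyl carbon. The position therefore spans a far wider range than the first two compounds showed, and compound 3 stands highest of the three, with both of its steps beyond the scatter. No supporting measurement bears on this result, and the size of these steps remains unexplained.

Going by these compounds, each large step replaces the aromatic ring and removes the carbonyl at once, so the share of each change remains open; a benzoyl group on the same nitrogen, or a pyridin-3-yl group attached directly to it, would separate the two. Also open, on these data alone, is how far an amine or a carboxylic acid on the phenyl would bring the number back down at this position.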